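The source may report more compounds than this note shows. Statements on the series, on what has been measured and on what is new or still open speak of the compounds shown alone.

Working notes on the series. Compound 1 `COc1ccc(N/C(CCNC2=CC(=O)c3ccccc3C2=O)=N\S(=O)(=O)c2ccc(C)cc2)cc1` and compound 2 `Cc1ccc(S(=O)(=O)/N=C(/CCNC2=CC(=O)c3ccccc3C2=O)Nc2ccccc2[N+](=O)[O-])cc1` share one core and differ only in the aryl group carried by the amine nitrogen. In an ADME assay on HEK293 cells (Homo sapiens) for cytotoxicity, read by MTT assay, with a stated time of 48 h (a lower number here means a stronger inhibitor, a higher number a weaker inhibitor), compound 1 gives 35100 nM. In this assay compound 2 gives 69600 nM. For the measured compounds named here, the single measured step, a 2.0-fold higher number from compound 1 to compound 2 (0.30 log units; within the scatter), lies within the scatter, so compound 2 stands at one end of the two numbers with compound 1 as its only neighbour, and the two cannot be told apart. Compound 3 `Cc1ccc(S(=O)(=O)/N=C(/CCNC2=CC(=O)c3ccccc3C2=O)Nc2ccc(Cl)cc2Cl)cc1` has not been measured. Its change from compound 2 is 2,4-dichlorophenyl in place of 2-nitrophenyl on an amine nitrogen. Going by the values given here, only the step from compound 1 to compound 2 bears on this: it exchanged the aryl group at the same place and did not move the number beyond the scatter. Among the compounds with values here, no measured compound carries a dichlorophenyl group, so nothing speaks for or against a move in either direction. The expected step is therefore a 1.4-fold lower number from compound 2 to compound 3 (0.14 log units; within the scatter), which is none beyond the scatter. Compound 3 is estimated at 50000 nM, with a range from 15000 nM to 150000 nM.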

Compound 3, half-maximal inhibitory concentration: 41900 nM
Beside the measured number, compound 3's estimate is 1.2-fold (0.08 log units) above it; measured number inside the range.
By their numbers in this assay, from the lowest: compounds 1, 3 and 2 (each within the scatter of the next).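

On the amine nitrogen whose other neighbour is the carbon with a double bond to nitrogen, exchanging 2-nitrophenyl for 2,4-dichlorophenyl in this assay gives a 1.7-fold lower number from compound 2 to compound 3 (0.22 log units; within the scatter), and exchanging 4-methoxyphenyl for 2,4-dichlorophenyl gives a 1.2-fold higher number from compound 1 to compound 3 (0.08 log units; within the scatter). This place has now taken a third aryl group, one carrying two chlorine atoms and no hydrogen-bond acceptors in place of the 2-nitrophenyl group with its two, and compounds 1, 2 and 3 still cannot be told apart at the scatter of this read-out. Nothing at hand accounts for this flat picture at the amine nitrogen, and no independent measurement bears on the result.

From the compounds shown here alone, all three compounds carry a substituted phenyl group at this place, so it stays open whether a benzyl group, a simple alkyl chain, or a phenyl group bearing a carboxylic acid or an amine would move the number beyond the scatter. The compounds shown also keep the rest of the shared core fixed, so they say nothing about how a longer chain on that core would behave.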